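This account rests on a few compounds, and the source may have more. Where it says the series, first, only, none or still open, it means among the compounds named here.

Three compounds have been measured in a physicochemical assay for lipophilicity, read by HPLC, using the shake flask method, in phosphate buffer, measured as octanol-water partition, with a stated time of 24 h, at pH 7.4, tested at 100 uM; on this read-out higher numbers stand for higher lipophilicity and lower numbers for lower lipophilicity:

Compound 1, `O=C(O)CC1COc2cc(OCc3cn(-c4c(Cl)cccc4Cl)nn3)ccc21`, gives 1.96.
Compound 2, `Cc1ccc(Cl)cc1-n1cc(COc2ccc3c(c2)OCC3CC(=O)O)nn1`, gives 2.08.
Compound 3, `O=C(O)COc1ccc(OCc2cn(-c3c(Cl)cccc3Cl)nn2)cc1F`, gives 2.16.

Compound 1 and compound 2 differ in a single place, (5-chloro-2-methylphenyl in place of 2,6-dichlorophenyl on an aromatic nitrogen). On this assay that change made a step of a number 0.12 log units higher from compound 1 to compound 2 (within the scatter), which stays within the usual scatter of repeated measurements. Compound 3 shares the triazole-linked side group with compound 1 but sits on another core; the difference between the two cores is not broken down here, and the two values of compound 1 and compound 3 simply lie close together.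

Compound 4, `Cc1ccc(Cl)cc1-n1cc(COc2ccc(OCC(=O)O)c(F)c2)nn1`, has not yet been measured. It stands to compound 3 as compound 2 stands to compound 1, the change being (5-chloro-2-methylphenyl in place of 2,6-dichlorophenyl on an aromatic nitrogen), at a place described in the same words in both pairs, so it is the same change. For compound 4 the expected step is a number 0.12 log units higher from compound 3 to compound 4 (within the scatter), resting on the step of a number 0.12 log units higher from compound 1 to compound 2 (within the scatter). Compound 4 is therefore estimated at 2.28, expected to fall between 1.95 and 2.6.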

Compound 4, distribution coefficient: 1.95
The estimate for compound 4 lay 0.33 log units above the measured number, and the stated range covers the measured number.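

In this assay, putting 5-chloro-2-methylphenyl in place of 2,6-dichlorophenyl gives a number 0.21 log units lower from compound 3 to compound 4 (within the scatter), and the same change on the core of compound 1 gives a number 0.12 log units higher from compound 1 to compound 2 (within the scatter). Since both steps lie within the usual scatter of repeated measurements, neither core shows a change that can be told apart from noise, so these two pairs give no sign that the core matters; they do not prove that the change would behave alike on other cores, or that no small real effect is hidden in the scatter. Nothing measured here bears on why the two steps read as they do.

Among the compounds shown here, only two groups on the aromatic nitrogen appear here, so it remains open how the read-out would respond to a ring carrying a trifluoromethyl or a nitrile. Also open, going by these compounds, is whether the same picture would hold on a core where an amide or an amine stands in place of the carboxylic acid.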